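The source may hold more compounds than are shown below. What is called first, only, known or untested is meant among the compounds shown, and "the series" means these compounds.

Of the compounds shown here, two that share one core have been measured in a functional assay on cells (Pituitary gland cell) for antagonist activity at Gonadotropin-releasing hormone receptor (Rattus norvegicus); on this read-out higher numbers stand for weaker inhibition and lower numbers for stronger inhibition. Compound 1 `Cc1cc(-c2c(O)nc3cc(Cl)c([N+](=O)[O-])cc3c2OCCC2CCCCN2)cc(C(C)O)c1` gives 63 nM in this assay, and compound 2 `O=[N+]([O-])c1cc2c(OCCC3CCCCN3)c(-c3ccccc3Cl)c(O)nc2cc1Cl` gives 360 nM. For the measured compounds named here, compound 2 therefore stands highest of the two numbers, with compound 1 as its only neighbour; the single measured step, a 5.7-fold higher number from compound 1 to compound 2 (0.76 log units; beyond the scatter), shows that exchanging the group on that aromatic carbon of the core moves the result by a modest amount. Compound 3 `O=[N+]([O-])c1cc2c(OCCC3CCCCN3)c(-c3cccs3)c(O)nc2cc1Cl` carries the next change at the same position: thiophen-2-yl in place of 2-chlorophenyl on an aromatic carbon. Going by the values given here, only that one step bears on the new compound, and it shows the result rising when the group on this carbon was exchanged, so a further exchange there is expected to leave the number near that of compound 2 or somewhat higher, as a 1.4-fold higher number from compound 2 to compound 3 (0.14 log units; within the scatter). Compound 3 is accordingly expected to give about 500 nM in this assay, most likely between 150 nM and 2000 nM.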

Compound 3, half-maximal inhibitory concentration: 220 nM
Estimate against measurement, compound 3: 2.3-fold (0.36 log units) above; the range from low to high includes it.
By their numbers in this assay, from the lowest: compound 1; then compounds 3 and 2 (each within the scatter of the next).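

In this assay, thiophen-2-yl, a five-membered aromatic ring with one sulfur, in place of 2-chlorophenyl gives a 1.6-fold lower number from compound 2 to compound 3 (0.21 log units; within the scatter) and so stays within the scatter: despite the different ring and the loss of the chlorine, these two groups cannot be told apart at this carbon. Thiophen-2-yl in place of 3-(1-hydroxyethyl)-5-methylphenyl gives a 3.5-fold higher number from compound 1 to compound 3 (0.54 log units; beyond the scatter) and is beyond the scatter, so the 3-(1-hydroxyethyl)-5-methylphenyl group of compound 1 now stands apart from two different groups rather than one. No measurement here offers an explanation for this pattern.

On these data alone, it remains open which part of that group goes with the lower number of compound 1; a phenyl ring carrying only the methyl or only the 1-hydroxyethyl group would separate the two. As far as these compounds go, how a ring bearing an amine or a carboxylic acid would read at this carbon is also open.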